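A few compounds are considered here, and "the series" means these few. Any claim that something is new, unique, unknown or untested is made for them only; others in the source may bear on it.

Measured so far:
compound 1 `Cn1cnc2c(Nc3ccccc3)ncnc21`, 0%
compound 2 `Cn1cnc2c(Nc3ccc(F)cc3)ncnc21`, 7%
compound 3 `Cn1c(-c2ccccc2)nc2c(Sc3ccccc3)ncnc21`, 1%

In an assay on isolated protein for inhibition of Rho-associated protein kinase 1 (Homo sapiens), tested at 30 uM (on this read-out higher numbers stand for more inhibition at the one concentration tested (going by the name of the read-out) and lower numbers for less inhibition), compound 1 gives 0% and compound 2 gives 7%. The change between them is fluoro in place of hydrogen on an aromatic carbon, and the step it made is a number 7 percentage points higher from compound 1 to compound 2 (within the scatter). Compound 3, which has a different core, gives 1% in this assay; how its core differs from that of compound 1 is not broken down here.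

Compound 4 `Cn1c(-c2ccccc2)nc2c(Sc3ccc(F)cc3)ncnc21` is not yet measured. It differs from compound 3 by fluoro in place of hydrogen on an aromatic carbon, the same change that was seen from compound 1 to compound 2, on the same kind of place. The step from compound 3 to compound 4 in this assay is therefore expected to be a number 5 percentage points higher from compound 3 to compound 4 (within the scatter), resting on the earlier step of a number 7 percentage points higher from compound 1 to compound 2 (within the scatter). On this basis compound 4 is estimated at 6%, with a likely range from -5% to 18%.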

Compound 4, a percentage reported as inhibition, at one concentration (the size of the read-out at that concentration, not a potency): 9%
Compound 4: the middle estimate sits 3 percentage points below what was measured; low and high end bracket the measured number.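

In this assay, fluoro in place of hydrogen on an aromatic carbon gave a number 8 percentage points higher from compound 3 to compound 4 (within the scatter), and the two cores do not differ in how they take this change: the same change on two cores in this assay, a number 7 percentage points higher (within the scatter) from compound 1 to compound 2 and a number 8 percentage points higher (within the scatter) from compound 3 to compound 4, 1 percentage points apart, within the scatter of two such steps. The change therefore carries from one of these cores to the other with no visible difference, but both steps lie within the scatter, so neither shows that the fluoro alters the read-out at all. Two cores are also a narrow base, and they say nothing of how the change would behave on other cores.

The compounds shown leave open whether a different group on that aromatic carbon, such as an amine or a carboxylic acid, would give a step beyond the scatter in this assay. They also leave open how a methoxy group or a chlorine atom there would compare with the fluoro.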